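Trimming a second amidoxime arm: cytotoxicity outlook for compound 4

This account rests on a few compounds, and the source may have more. Where it says the series, first, only, none or still open, it means among the compounds named here.

Compound 1 `CC1(Cc2ccccc2)CC(S(=O)(=O)c2cccc(C(F)(F)F)c2)=C(c2ccc(/C(N)=N\O)cc2)O1` gives 14500 nM in an ADME assay on J774.A1 cells (Mus musculus) for cytotoxicity, read by MTT assay, with a stated time of 72 h; on this read-out higher numbers stand for lower toxicity in this test and lower numbers for higher toxicity in this test.
Compound 2 `CC1(c2ccc(-c3ccc(/C(N)=N\O)cc3)cc2)CC(S(=O)(=O)c2ccc(F)cc2)=C(c2ccc(/C(N)=N\O)cc2)O1` gives 3940 nM in this assay.
Compound 3 `CC1(Cc2ccccc2)CC(S(=O)(=O)c2ccccc2C(F)(F)F)=C(c2ccc(/C(N)=N\O)cc2)O1` gives 23500 nM in this assay.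

Compound 2 has the lowest number of the three in this assay; compound 1 stands higher by a margin beyond the scatter, and compound 3 higher still. Among the compounds with values here, the single measured step, a 1.6-fold higher number from compound 1 to compound 3 (0.21 log units; within the scatter), concerns the trifluoromethyl position on the sulfonyl aryl ring and stays within the scatter; it does not touch the place that changes here.

Compound 4 `CC1(c2ccc(Br)cc2)CC(S(=O)(=O)c2ccc(F)cc2)=C(c2ccc(/C(N)=N\O)cc2)O1` differs from compound 2 in that (one bromine atom in place of a group of 10 heavy atoms (7 carbon, 2 nitrogen, 1 oxygen; one six-membered aromatic ring of carbon only), on an aromatic carbon). Within the data shown here, no measured pair changes this position directly. What the data do show is that compound 1 and compound 3, which each carry one amidoxime on the shared core, sit well above compound 2, which carries two. Compound 4 likewise carries one, so its number in this assay is expected to rise toward those of compound 1 and compound 3, a step of a 2.5-fold higher number from compound 2 to compound 4 (0.40 log units; beyond the scatter). The estimate for compound 4 is therefore 10000 nM, within 3500 nM to 30000 nM.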

Compound 4, half-maximal cytotoxic concentration: 10500 nM
Beside the measured number, compound 4's estimate is 1.1-fold (0.02 log units) below it; low and high end bracket the measured number.
By their numbers in this assay, from the lowest: compound 2; then compounds 4, 1 and 3 (each within the scatter of the next, the first and the last beyond it).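

In this assay, the place on the aromatic ring para to a large group now has a direct measurement: one bromine atom in place of the group of 10 heavy atoms gives a 2.7-fold higher number from compound 2 to compound 4 (0.43 log units; beyond the scatter). Unlike the trifluoromethyl shift on the sulfonyl aryl ring, this change lies beyond the scatter, so the number in this test does respond to what sits at this place. Nothing measured here accounts for the rise.

The aromatic ring and the amidoxime leave together in this change, so the compounds shown do not separate the contribution of one from that of the other. Also open, as far as these compounds go, is where the number would stand with a plain phenyl ring, which keeps the ring without the amidoxime, or with an amine or a carboxylic acid at this place.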